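Adding a second fluoro to a cytotoxic peroxide

A few compounds are considered here, and "the series" means these few. Any claim that something is new, unique, unknown or untested is made for them only; others in the source may bear on it.

Measured so far in a functional assay on FM3A cells (Mus musculus) for cytotoxicity; a lower number here means that less compound is needed, a higher number that more compound is needed for the effect:
compound 1 `c1ccc(C2OOC3CCCC(c4ccccc4)(OO2)O3)cc1`: 50000 nM
compound 2 `CCC(CC)C1OOC2CCCC(c3ccccc3)(OO1)O2`: 33000 nM
compound 3 `Fc1ccc(C23CCCC(OOC(c4ccccc4)OO2)O3)cc1`: 8100 nM

Among these three, compound 3 has the lowest number at 8100 nM, so it needs the least compound for the effect. Compound 4 `Fc1ccc(C2OOC3CCCC(c4ccc(F)cc4)(OO2)O3)cc1` keeps the core of compound 3 and turns its remaining phenyl into 4-fluorophenyl: fluoro in place of hydrogen on an aromatic carbon. Among the measured compounds shown here, the most relevant measurement is the one earlier change of the same kind, fluoro in place of hydrogen on an aromatic carbon, which gave a 6.2-fold lower number from compound 1 to compound 3 (0.79 log units; beyond the scatter). The other measured change, pentan-3-yl in place of phenyl, gave a 1.5-fold lower number from compound 1 to compound 2 (0.18 log units; within the scatter), but it is a different kind of swap and says little here. One precedent is thin evidence, and a second fluoro need not repeat the first. A smaller step in the same direction is therefore expected in this assay, and a result within the scatter would be no surprise. The expected change is a 2.0-fold lower number from compound 3 to compound 4 (0.31 log units; beyond the scatter). Compound 4 is estimated at 4000 nM, with an expected range from 1300 nM to 12000 nM.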

Compound 4, half-maximal effective concentration: 9000 nM
The estimate for compound 4 lay 2.3-fold (0.35 log units) below the measured number, and the stated range covers the measured number.
By their numbers in this assay, from the lowest: compounds 3 and 4 (each within the scatter of the next); then compounds 2 and 1 (each within the scatter of the next).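

In this assay, fluoro in place of hydrogen on an aromatic carbon does not have the same effect each time: one such swap gave a 6.2-fold lower number from compound 1 to compound 3 (0.79 log units; beyond the scatter), while making it on the remaining phenyl gave a 1.1-fold higher number from compound 3 to compound 4 (0.05 log units; within the scatter). Turning that phenyl into 4-fluorophenyl thus leaves the number within the scatter, so the earlier step cannot simply be added again when the swap is repeated on the same molecule. Nothing available explains the difference between these two steps.

Fluoro is the only replacement for hydrogen shown at this place on the remaining phenyl, so chloro, methoxy or a carboxylic acid there could still move the number. On these data alone, whether compound 2, with its pentan-3-yl group, would respond to a fluoro swap on its phenyl also stays open.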